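This account rests on a few compounds, and the source may have more. Where it says the series, first, only, none or still open, it means among the compounds named here.

Values measured in an ADME assay on S9 fraction from liver (Rattus norvegicus) for metabolic stability, with a stated time of 1 h; a lower number here means that less of the compound is left, a higher number that more of the compound is left:

- compound 1 `N#Cc1cnc(NCc2cnccc2C(F)(F)F)cc1N[C@H]1C[C@@H](O)C1` gives 70%
- compound 2 `N#Cc1cnc(NCc2cnccc2C(F)(F)F)cc1NC[C@H]1C[C@@H](O)C1` gives 44%
- compound 3 `N#Cc1cnc(NCc2cnccc2C(F)(F)F)cc1NC[C@H]1CC[C@H](O)CC1` gives 6%

Compound 3 has the lowest number of the three, and compound 1 and compound 2 both stand above it beyond the scatter. Compound 4 `CO[C@H]1CC[C@@H](CNc2cc(NCc3cnccc3C(F)(F)F)ncc2C#N)CC1` differs from it in one place: 4-methoxycyclohexyl in place of 4-hydroxycyclohexyl on a saturated chain carbon bound to a nitrogen on an aromatic ring, with 4-methoxycyclohexyl in place of 4-hydroxycyclohexyl on a saturated chain carbon bound to a nitrogen on an aromatic ring.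

Among the compounds with values here, no measured step makes this exchange. The steps that come closest alter the same substituent in other ways: the modest a number 26 percentage points lower from compound 1 to compound 2 (beyond the scatter), the large a number 38 percentage points lower from compound 2 to compound 3 (beyond the scatter) and the large a number 64 percentage points lower from compound 1 to compound 3 (beyond the scatter). They show that this assay responds to changes in this substituent, but they give no direction for this one. With compound 3 at 6% little of the scale remains below it, so no step beyond the scatter is expected, though a rise cannot be excluded. The expected result is a number 2 percentage points higher from compound 3 to compound 4 (within the scatter) in this read-out. Compound 4 is estimated at 8%, with an expected range from 2% to 25%.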

Compound 4, percent of the compound remaining: 2%
Compound 4: middle estimate off by 6 percentage points, on the high side; measured number inside the range.
By their numbers in this assay, from the lowest: compounds 4 and 3 (each within the scatter of the next); then compound 2; then compound 1.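

In this assay, 4-methoxycyclohexyl in place of 4-hydroxycyclohexyl on a saturated chain carbon bound to a nitrogen on an aromatic ring gives a number 4 percentage points lower from compound 3 to compound 4 (within the scatter), so removing the hydrogen-bond donor of this group does not separate the two compounds in this read-out. The methoxy compound keeps the large distance already seen for the hydroxy compound from the cyclobutyl compounds, with a number 42 percentage points lower from compound 2 to compound 4 (beyond the scatter) and a number 68 percentage points lower from compound 1 to compound 4 (beyond the scatter). Nothing given here explains these steps.

From the compounds shown here alone, both cyclohexyl compounds lie so near the bottom of the scale that the exchange could have little visible effect here, so its effect on a more stable compound remains open. Going by these compounds, whether 3-methoxycyclobutyl would behave like 3-hydroxycyclobutyl in compound 1 or compound 2, or how an amine in place of the hydroxyl would read, also remains open.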